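Aryl swap on the shared core: naphthalen-1-yl to 3-nitrophenyl

The source may hold more compounds than are shown below. What is called first, only, known or untested is meant among the compounds shown, and "the series" means these compounds.

Measured in a functional assay on MCF7 cells (Homo sapiens) for antiproliferative activity, read by MTT assay, with stated times of 24 h and 72 h; on this read-out lower numbers stand for stronger inhibition and higher numbers for weaker inhibition:
- compound 1 `COc1cccc([C@@H]2[C@H](Oc3ccccc3)C(=O)N2c2cc(OC)c(OC)c(OC)c2)c1`: 171000 nM
- compound 2 `COc1ccc([C@@H]2[C@H](Oc3ccccc3)C(=O)N2c2cc(OC)c(OC)c(OC)c2)cc1OC`: 26000 nM
- compound 3 `COc1cc(N2C(=O)[C@@H](Oc3ccccc3)[C@H]2c2cccc3ccccc23)cc(OC)c1OC`: 53000 nM

Compound 3 holds the second highest of the three numbers, as shown by a 2.0-fold higher number from compound 2 to compound 3 (0.31 log units; beyond the scatter) and by a 3.2-fold lower number from compound 1 to compound 3 (0.51 log units; beyond the scatter). Compound 4 `COc1cc(N2C(=O)[C@@H](Oc3ccccc3)[C@H]2c2cccc([N+](=O)[O-])c2)cc(OC)c1OC` differs from compound 3 at one place, with 3-nitrophenyl in place of naphthalen-1-yl on a saturated ring carbon.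

Within the data shown here, no measured compound carries a nitro group, so no step reads on this group directly. Among the measured compounds shown here, three steps bear on the same saturated ring carbon, all modest: a 6.6-fold lower number from compound 1 to compound 2 (0.82 log units; beyond the scatter), a 3.2-fold lower number from compound 1 to compound 3 (0.51 log units; beyond the scatter) and a 2.0-fold higher number from compound 2 to compound 3 (0.31 log units; beyond the scatter). Compound 1, with 3-methoxyphenyl, is the closest measured match to 3-nitrophenyl, and it stands at 171000 nM. Compound 2 goes against any simple reading of phenyl against naphthalen-1-yl, since it stands at 26000 nM. A modest move to a higher number in this assay is therefore expected, namely a 2.1-fold higher number from compound 3 to compound 4 (0.32 log units; beyond the scatter). For compound 4 the estimated value is 110000 nM, with an expected range of 35000 nM to 300000 nM.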

Compound 4, half-maximal inhibitory concentration: 30000 nM
Compound 4: middle estimate off by 3.7-fold (0.56 log units), on the high side, outside the stated range (below it).
By their numbers in this assay, from the lowest: compounds 2, 4 and 3 (each within the scatter of the next, the first and the last beyond it); then compound 1.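

Notes on the series: in this assay, the aryl group on this saturated ring carbon is not interchangeable even when the single-ring form is kept, since nitro in place of methoxy on an aromatic carbon gives a step beyond the scatter (a 5.7-fold lower number from compound 1 to compound 4 (0.76 log units; beyond the scatter)). This makes the high number of compound 1 specific to 3-methoxyphenyl among the aryl groups shown, and it does not extend to every singly substituted phenyl. Compound 4 cannot be separated from either of the two neighbouring compounds (a 1.8-fold lower number from compound 3 to compound 4 (0.25 log units; within the scatter) and a 1.2-fold higher number from compound 2 to compound 4 (0.06 log units; within the scatter), both within the scatter), even though the step between those two compounds is printed as just beyond it, and nothing measured on these compounds accounts for any of this.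

Going by these compounds, it remains open whether an amine or a carboxylic acid on the same aromatic carbon would track compound 4 or compound 1. The compounds shown also keep the phenoxy group and the ring nitrogen substituent fixed throughout, so it is unknown whether the gap between 3-nitrophenyl and 3-methoxyphenyl would persist with, for example, a methoxy group in place of the phenoxy group.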